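The source may report more compounds than this note shows. Statements on the series, on what has been measured and on what is new or still open speak of the compounds shown alone.

Of the compounds shown here, three built on one shared core have so far been tested in a functional assay on U-937 cells (Homo sapiens) for cytotoxicity, read by CCK-8 assay, with a stated time of 72 h; on this read-out lower numbers stand for stronger inhibition and higher numbers for weaker inhibition. Compound 1 `C=CCn1c(=O)/c(=C\c2cccc(F)c2)[nH]c(=O)/c1=C\c1ccccc1OC` gives 2500 nM. Compound 2 `C=CCn1c(=O)/c(=C\c2cccc(Cl)c2Cl)[nH]c(=O)/c1=C\c1ccccc1OC` gives 500 nM, and compound 3 `C=CCn1c(=O)/c(=C\c2cccc(Br)c2)[nH]c(=O)/c1=C\c1ccccc1OC` gives 1100 nM. Among these three numbers compound 3 stands second highest: the nearest is compound 2, with a 2.2-fold higher number from compound 2 to compound 3 (0.34 log units; beyond the scatter), and the furthest is compound 1, with a 2.3-fold lower number from compound 1 to compound 3 (0.36 log units; beyond the scatter).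

Compound 4 `C=CCn1c(=O)/c(=C\c2ccc(F)c(Br)c2)[nH]c(=O)/c1=C\c1ccccc1OC` differs from compound 3 by fluoro in place of hydrogen on an aromatic carbon. Among the measured compounds shown here, two measured steps bear on this change. The first is a 2.3-fold lower number from compound 1 to compound 3 (0.36 log units; beyond the scatter), which shows that a larger halogen on that ring lowered the number. The second is a 5.0-fold lower number from compound 1 to compound 2 (0.70 log units; beyond the scatter), where a second halogen joined the first on the same ring and gave the lowest number of the three. Both point the same way, so a further halogen on the ring of compound 3 is expected to lower the number again, though by a modest amount rather than a large one, since each of those steps was itself modest.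

Compound 4 is therefore estimated to give 700 nM in this assay, with a likely range from 300 nM to 1800 nM. The step this estimate implies is a 1.6-fold lower number from compound 3 to compound 4 (0.20 log units; within the scatter), an expected modest drop.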

Compound 4, half-maximal inhibitory concentration: "not active" (no number reported)
Nothing numeric was reported for compound 4, so the estimate cannot be set against anything.
By their numbers in this assay, from the lowest: compound 2; then compound 3; then compound 1.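

In this assay, among the compounds shown here, compound 4 is recorded only as "not active", with no number, so no step from compound 3 to compound 4 can be read. The compounds shown leave open how the 3-bromo-4-fluorophenyl group of compound 4 compares in number with the 3-bromophenyl group of compound 3. No supporting data explain this result.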